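Swapping the benzyl substituent in an isatin series

A few compounds are considered here, and "the series" means these few. Any claim that something is new, unique, unknown or untested is made for them only; others in the source may bear on it.

The shared core carries a 4-methoxyphenyl group in compound 2 `COc1ccc(-c2ccc3c(c2)C(=O)C(=O)N3Cc2ccc(Cl)cc2)cc1` and a 4-chlorobenzyl group on its ring nitrogen. In a functional assay on HepG2 cells (Homo sapiens) for antiproliferative activity, read by MTT assay, with a stated time of 48 h (a lower number here means a stronger inhibitor, a higher number a weaker inhibitor), compound 2 gives 250 nM, the lowest of the two numbers recorded. Its nearest neighbour is compound 1 `O=C1Nc2ccc(-c3ccc(C(F)(F)F)cc3)cc2C1=O`, which lacks both the methoxy group and the benzyl group; in this assay compound 1 gives 5430 nM, and the gap between the two lies beyond the scatter.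

Compound 3 `COc1ccc(-c2ccc3c(c2)C(=O)C(=O)N3Cc2cccc(OC)c2)cc1` has not yet been measured. It differs from compound 2 in one place: 3-methoxyphenyl in place of 4-chlorophenyl on a saturated chain carbon bound to an amide-type nitrogen in a ring. Going by the values given here, no measured pair in this set shows that change, so its effect is not known from these data. The expected step from compound 2 to compound 3 in this assay is a 1.6-fold higher number from compound 2 to compound 3 (0.20 log units; within the scatter), a modest weakening at most. Compound 3 is therefore expected to give about 400 nM, within a range from 150 nM to 1200 nM.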

Compound 3, half-maximal inhibitory concentration: 700 nM
Estimate against measurement, compound 3: 1.8-fold (0.24 log units) below; measured number inside the range.
By their numbers in this assay, from the lowest: compound 2; then compound 3; then compound 1.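

At this position the benzyl group is not interchangeable: in this assay, 3-methoxybenzyl in place of 4-chlorobenzyl gives a 2.8-fold higher number from compound 2 to compound 3 (0.45 log units; beyond the scatter), a modest step but one beyond the scatter. Going by these compounds alone, this is the first reading of a change in one place, since the gap between the earlier compounds spanned two differences and could not be assigned to the benzyl substituent. No supporting data are available to explain this step.

Going by these compounds, the change replaces the chloro group with a methoxy group and also moves the substituent, so what a 3-chlorobenzyl or 4-methoxybenzyl group would give remains open, and the two effects cannot be separated. Also open, on these data alone, is how an amine or a carboxylic acid on the benzyl ring, or a longer chain in place of benzyl, would read in this assay.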